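The source may report more compounds than this note shows. Statements on the series, on what has been measured and on what is new or still open speak of the compounds shown alone.

Two compounds share one core and differ only at a saturated chain carbon bound to an aromatic nitrogen. Compound 1 `Cn1c(Cc2nn(C)c(=O)c3ccccc23)nnc1SCC(=O)Nc1ccc(Cl)cc1Cl` carries hydrogen there, and in an assay on 32D cells for inhibition of interleukin-15 (Mus musculus), read by resazurin assay, with stated times of 30 min and 2.5 days, in the presence of a further agent that is not named here (a higher number here means a weaker inhibitor, a lower number a stronger inhibitor), compound 1 gives 22500 nM. Compound 2 `CCOC(CCn1c(Cc2nn(C)c(=O)c3ccccc23)nnc1SCC(=O)Nc1ccc(Cl)cc1Cl)OCC` carries 2,2-diethoxyethyl in that place. In this assay compound 2 reaches only a limit of the assay, > 30000 nM. Within the data shown here, the one measured step, an at least 1.3-fold higher number from compound 1 to compound 2 (0.12 log units; that floor lies within the scatter), is therefore known only as a floor, because one of the two values sits at the limit of > 30000 nM in this assay, at which 1 of the 2 values shown sits. Compound 3 `Cn1nc(Cc2nnc(SCC(=O)Nc3ccc(Cl)cc3Cl)n2CCC=O)c2ccccc2c1=O` has not yet been measured; it differs from compound 2 by formyl in place of diethoxymethyl on a saturated chain carbon, two bonds along the chain from an aromatic nitrogen. Among the measured compounds shown here, this change lies on the same chain that separates compound 1 from compound 2, and the only step measured on that chain was small by its floor and weak at both ends, so nothing here points to a strong gain or loss. The expected step is a number no higher from compound 2 to compound 3 (the limit leaves the size open), which is none beyond the scatter. Compound 3 is estimated to give 30000 nM in this assay, between 12000 nM and 80000 nM.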

Compound 3, half-maximal inhibitory concentration: 6000 nM
The estimate for compound 3 lay 5.0-fold (0.70 log units) above the measured number, and the stated range ends above it.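

The earlier compounds shown here showed no change beyond the scatter on this chain, whereas in this assay swapping the end group on a saturated chain carbon, two bonds along the chain from an aromatic nitrogen, gives an at least 5.0-fold lower number from compound 2 to compound 3 (0.69 log units; beyond the scatter). The size of that step is known only as a floor, because compound 2 sits at a limit: the limit of > 30000 nM in this assay, at which 1 of the 3 values shown sits. The comparison with the hydrogen-bearing parent has no such limit and gives a 3.8-fold lower number from compound 1 to compound 3 (0.57 log units; beyond the scatter), so this chain can carry a group that improves on hydrogen, and compound 3 is the strongest of the three, though still a modest gain on a weak starting point.

The change from compound 2 to compound 3 removes diethoxymethyl and brings in formyl in a single move, so these compounds cannot tell whether the gain comes from having the formyl group itself or simply from losing the larger diethoxymethyl group. A plain propyl chain, a 3-hydroxypropyl chain or a carboxylic acid at the chain end would be needed to separate those two readings.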